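Trading a thiocarbonyl side group for bromomethyl

The source may hold more compounds than are shown below. What is called first, only, known or untested is meant among the compounds shown, and "the series" means these compounds.

In a functional assay on ECa-109 cells for inhibition, with ECa-109 cell line (Homo sapiens) as the target, read by MTT assay, with a stated time of 48 h (a higher number here means a weaker inhibitor, a lower number a stronger inhibitor), compound 1 (`COc1ccc(-c2coc3cc(OCCCSC(=S)N4CCCC4)ccc3c2=O)cc1`) gives 30800 nM, and compound 2 (`COc1ccc(-c2coc3cc(OCCCSC(=S)N4CCOCC4)ccc3c2=O)cc1`) gives 34000 nM. Going by the values given here, these two values lie within the scatter of each other, so compound 2 stands level with the only other compound measured, and both numbers are high on a scale where lower means stronger.

Compound 3 (`COc1ccc(-c2coc3cc(OCCCCBr)ccc3c2=O)cc1`) keeps the shared core but ends its chain differently, with bromomethyl entering. The change from compound 2 is a group of 2 heavy atoms (1 carbon, 1 bromine; no ring) in place of a group of 9 heavy atoms (5 carbon, 1 nitrogen, 1 oxygen, 2 sulfur; one six-membered non-aromatic ring with 2 hetero atoms), on a saturated chain carbon, three bonds along the chain from an oxygen on an aromatic ring.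

Among the compounds with values here, only one measured step bears on this. Exchanging one ring of the side group for another gave a 1.1-fold higher number from compound 1 to compound 2 (0.04 log units; within the scatter). That step shows that one ring could replace the other with no visible effect in this assay. It says nothing about removing the whole group, so the data offer only weak guidance and no firm direction. The step expected is a 1.2-fold higher number from compound 2 to compound 3 (0.07 log units; within the scatter), a small one, held with wide uncertainty. For compound 3 the estimated value is 40000 nM, with an expected range from 14000 nM to 100000 nM.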

Compound 3, half-maximal inhibitory concentration: 66300 nM
Beside the measured number, compound 3's estimate is 1.7-fold (0.22 log units) below it; the measured number falls inside the stated range.
By their numbers in this assay, from the lowest: compounds 1, 2 and 3 (each within the scatter of the next, the first and the last beyond it).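

Going by these compounds alone, until now, only one ring on the thiocarbonyl carbon had been exchanged for another; compound 3 is the first case here in which the whole side group gives way to bromomethyl, on a saturated chain carbon, three bonds along the chain from an oxygen on an aromatic ring. In this assay, this larger change gives a 2.0-fold higher number from compound 2 to compound 3 (0.29 log units; within the scatter) and a 2.2-fold higher number from compound 1 to compound 3 (0.33 log units; beyond the scatter), so it is only a modest loss against the pyrrolidine-bearing compound and cannot be told apart from the scatter against the morpholine-bearing one, and neither comparison shows a gain from removing the side group. No measurement is available to explain these differences.

The compounds shown do not reveal which part of the departing group counts, whether the ring, the thiocarbonyl or the sulfur in the chain, and a simple amine or a carboxylic acid at the same chain end would help to separate these possibilities. They also leave open whether a longer chain, or any other end group, could bring the number well below the high values seen so far.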